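This account rests on a few compounds, and the source may have more. Where it says the series, first, only, none or still open, it means among the compounds named here.

Series notes. The shared core, seen in compound 1 `CC(C)(C)OC(=O)NCC1CCCN(C(=O)CN2CN(c3ccccc3)C3(CCN(C(=O)c4ccc(C5CCCCC5)cc4)CC3)C2=O)C1`, compound 2 `CS(=O)(=O)N1CCN(C(=O)CN2CN(c3ccccc3)C3(CCN(C(=O)c4ccc(C5CCCCC5)cc4)CC3)C2=O)CC1` and compound 3 `CC(C)(C)OC(=O)NCCNC(=O)CN1CN(c2ccccc2)C2(CCN(C(=O)c3ccc(C4CCCCC4)cc3)CC2)C1=O`, carries a varied amide substituent on a carbonyl carbon. In an assay on HEK293 cells for displacement of a labelled ligand from NPC1-like intracellular cholesterol transporter 1 (Homo sapiens) (on this read-out higher numbers stand for weaker inhibition and lower numbers for stronger inhibition), compound 1 gives 3800 nM, compound 2 gives 6300 nM and compound 3 gives 5500 nM. Compound 3 stands second highest of the three numbers; its nearest neighbour is compound 2 and its furthest is compound 1, and both gaps are within the scatter. Among the measured compounds shown here, the single step measured at this position is a 1.1-fold lower number from compound 2 to compound 3 (0.06 log units; within the scatter).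

Compound 4 `CCOC(=O)C1CCCN(C(=O)CN2CN(c3ccccc3)C3(CCN(C(=O)c4ccc(C5CCCCC5)cc4)CC3)C2=O)C1` differs from compound 3 by 3-(ethoxycarbonyl)piperidin-1-yl in place of (2-((tert-butoxycarbonyl)amino)ethyl)amino on a carbonyl carbon. For the measured compounds named here, only that one step bears on this change, and it swapped one amide substituent for another without moving the number beyond the scatter. Compound 1 likewise gives 3800 nM, inside the same narrow band. No step beyond the scatter is therefore expected from this replacement. Compound 4 is estimated at 4500 nM (range 1800 nM to 11000 nM), which would mean an expected step of a 1.2-fold lower number from compound 3 to compound 4 (0.09 log units; within the scatter).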

Compound 4, half-maximal inhibitory concentration: 4200 nM
Compound 4: middle estimate off by 1.1-fold (0.03 log units), on the high side; the range from low to high includes it.
By their numbers in this assay, from the lowest: compounds 1, 4, 3 and 2 (each within the scatter of the next).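

In this assay, the change to 3-(ethoxycarbonyl)piperidin-1-yl on the carbonyl carbon removes the hydrogen-bond donors of (2-((tert-butoxycarbonyl)amino)ethyl)amino and brings in a six-membered non-aromatic ring, yet it gives only a 1.3-fold lower number from compound 3 to compound 4 (0.12 log units; within the scatter) and so stays within the scatter. The same group in place of 4-(methylsulfonyl)piperazin-1-yl gives a 1.5-fold lower number from compound 2 to compound 4 (0.18 log units; within the scatter) and also stays within the scatter, while ethoxycarbonyl in place of ((tert-butoxycarbonyl)amino)methyl, a change on a saturated ring carbon of the substituent, gives a 1.1-fold higher number from compound 1 to compound 4 (0.04 log units; within the scatter) and likewise stays within the scatter. No supporting measurement bears on these results.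

Still open, going by these compounds, is whether a carboxylic acid or an aminomethyl group on that saturated ring carbon would move the number beyond the scatter. The same question stands for a dimethylamino group on the carbonyl carbon.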